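Moving one methoxy group on compound 1

The source may hold more compounds than are shown below. What is called first, only, known or untested is meant among the compounds shown, and "the series" means these compounds.

Measured in a functional assay on HepG2 cells (Homo sapiens) for antiproliferative activity, read by MTT assay, with a stated time of 72 h; a higher number here means a weaker inhibitor, a lower number a stronger inhibitor:
- compound 1 `COc1ccc(N2C(=O)COc3ccc(-c4ccc(O)cc4)cc32)cc1`: 10800 nM
- compound 2 `COc1ccc(N2C(=O)COc3ccc(-c4cnc(Cl)c(NS(=O)(=O)c5ccc(F)cc5)c4)cc32)cc1`: > 40000 nM (a limit of the assay, not a number)
- compound 3 `COc1cccc(N2C(=O)COc3ccc(-c4cccc(NS(=O)(=O)c5ccc(F)cc5)c4)cc32)c1`: > 40000 nM (a limit of the assay, not a number)

Compound 1 is the only one of the three with a true number, so it has no measured neighbour to be ranked against. The other two results mark (the limit of > 40000 nM in this assay, at which 2 of the 3 values shown sit).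

Compound 4 `COc1cccc(N2C(=O)COc3ccc(-c4ccc(O)cc4)cc32)c1` has not yet been measured. It differs from compound 1 in one place, with 3-methoxyphenyl in place of 4-methoxyphenyl on an amide-type nitrogen in a ring. The two compounds have the same atoms, joined differently.

Among the compounds with values here, no measured pair of compounds shows this change alone, so the data give no direct size for it. The best starting point is compound 1 at 10800 nM, and with so little to go on, no shift beyond the usual scatter is expected in this assay. The expected step of a 1.1-fold higher number from compound 1 to compound 4 (0.05 log units; within the scatter) is therefore small, though the uncertainty around it is wide. For compound 4 the estimated value is 12000 nM, with an expected range of 4500 nM to 32000 nM.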

Compound 4, half-maximal inhibitory concentration: 26100 nM
The estimate for compound 4 lay 2.2-fold (0.34 log units) below the measured number, and the stated range covers the measured number.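

In this assay, the placement of the methoxy group on this ring turns out to matter: 3-methoxyphenyl in place of 4-methoxyphenyl on the amide-type nitrogen gives a 2.4-fold higher number from compound 1 to compound 4 (0.38 log units; beyond the scatter). The two groups have the same atoms and the same counts of hydrogen-bond donors and acceptors, so the shift comes from rearrangement alone, and of the two placements the 4-methoxyphenyl of compound 1 gives the stronger result here. The step can be read in full since compound 4 keeps a true number, unlike the two results held at a limit of the assay: the limit of > 40000 nM in this assay, at which 2 of the 4 values shown sit.

The compounds shown cover only these two placements of the methoxy group, so it remains open how a plain phenyl ring, an ethoxy group or an amine on the same ring would compare. This single pair also gives no reason for the shift and cannot say whether the same change would have the same size on compounds that differ elsewhere from compound 1.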